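Exchanging 4-methoxyphenyl for 2-methoxyphenyl on the ring nitrogen

A few compounds are considered here, and "the series" means these few. Any claim that something is new, unique, unknown or untested is made for them only; others in the source may bear on it.

Compound 1 `CCN1CCN(CC(=O)Nc2nc3ccccc3[nH]2)CC1`: 35.7%
Compound 2 `O=C(CN1CCN(c2ccccc2F)CC1)Nc1nc2ccccc2[nH]1`: 37.4%
Compound 3 `COc1ccc(N2CCN(CC(=O)Nc3nc4ccccc4[nH]3)CC2)cc1`: 25.8%

Of the compounds shown here, three sharing one core have been measured in a functional assay, read by spectrophotometry, with a stated time of 30 min, tested at 50 ug/mL; a lower number here means a weaker effect, a higher number a stronger effect of the compound at the concentration tested. Compound 3 gives the lowest of the three numbers, with compound 1 nearest; the step of a number 9.9 percentage points lower from compound 1 to compound 3 (within the scatter) lies within the scatter, so the two cannot be ordered. Against compound 2 the gap is larger: the step of a number 11.6 percentage points lower from compound 2 to compound 3 (beyond the scatter) is beyond the scatter, though modest. Compound 1 and compound 2 differ by a number 1.7 percentage points higher from compound 1 to compound 2 (within the scatter), which is within the scatter.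

Compound 4 `COc1ccccc1N1CCN(CC(=O)Nc2nc3ccccc3[nH]2)CC1` has not yet been measured. It differs from compound 3 by 2-methoxyphenyl in place of 4-methoxyphenyl on an amine nitrogen in a ring.

The step that bears most directly on this change is a number 11.6 percentage points lower from compound 2 to compound 3 (beyond the scatter), where a 2-fluorophenyl group on the same ring nitrogen gave a modestly higher number than the 4-methoxyphenyl group of compound 3. The step of a number 9.9 percentage points lower from compound 1 to compound 3 (within the scatter) also places compound 3 at the low end. Within the data shown here, on this basis a modest rise in this assay is expected on going from compound 3 to compound 4, though no measured pair separates the 2-methoxyphenyl group from the 4-methoxyphenyl group directly, so the expected step of a number 6.2 percentage points higher from compound 3 to compound 4 (within the scatter) may well fall within the scatter. Compound 4 is estimated at 32%, in a range from 20% to 44%.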

Compound 4, a percentage reported as activity, at one concentration (the size of the read-out at that concentration, not a potency): 35.7%
Compound 4: the middle estimate sits 3.7 percentage points below what was measured; the measured number falls inside the stated range.
By their numbers in this assay, from the lowest: compounds 3, 1, 4 and 2 (each within the scatter of the next, the first and the last beyond it).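

In this assay, among these compounds, the first direct pair for these two groups shows a number 9.9 percentage points higher from compound 3 to compound 4 (within the scatter) and so does not separate the 2-methoxyphenyl group from the 4-methoxyphenyl group on the ring nitrogen. With the 2-methoxyphenyl group in place, the comparison with the fluoro analogue gives a number 1.7 percentage points lower from compound 2 to compound 4 (within the scatter) and the comparison with the ethyl analogue gives no change at the digits printed from compound 1 to compound 4 (within the scatter), so compound 4 cannot be told apart from any of the other three compounds. The only gap beyond the scatter among these four remains a number 11.6 percentage points lower from compound 2 to compound 3 (beyond the scatter) and it stands alone, which means that the set offers no clear ordering of the groups at this position.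

On these data alone, whether a benzyl group, a longer alkyl chain or a carboxylic acid on the phenyl ring would take the read-out clear of this narrow band remains open, as does how these compounds would behave at any other concentration. Nothing given here accounts for the numbers seen at this ring nitrogen.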